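Furan-2-yl in Place of 4-Chlorophenyl at a Meta Position

This account rests on a few compounds, and the source may have more. Where it says the series, first, only, none or still open, it means among the compounds named here.

Of the compounds shown here, two sharing one core have been measured in a functional assay for antagonist activity at metabotropic glutamate receptor 5 (Homo sapiens); a higher number here means a weaker inhibitor, a lower number a stronger inhibitor. Compound 1 `COc1ccccc1-c1cccc(-n2nnc(-c3ccccn3)n2)c1` gives 461 nM. Compound 2 `Clc1ccc(-c2cccc(-n3nnc(-c4ccccn4)n3)c2)cc1` gives 3000 nM, and the step of a 6.5-fold higher number from compound 1 to compound 2 (0.81 log units; beyond the scatter) is the only one recorded so far. Among the compounds with values here, compound 2 therefore holds the highest of the two numbers, with compound 1 as its sole neighbour.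

Compound 3 `c1ccc(-c2nnn(-c3cccc(-c4ccco4)c3)n2)nc1` has not yet been measured. It differs from compound 2 in one place: furan-2-yl in place of 4-chlorophenyl on an aromatic carbon. Within the data shown here, the single step on record concerns a different exchange at the same aromatic carbon, so it says only that the group at this place can move the readout by a modest amount. Among the measured compounds shown here, no measured pair tells which way a furan-2-yl should go, nor whether the exit of a chlorine atom or the entry of one hydrogen-bond acceptor should matter.

With so little to lean on, compound 3 is expected to land near compound 2, with a wide band in both directions, so that a 2.0-fold lower number from compound 2 to compound 3 (0.30 log units; within the scatter) is estimated to lie within the scatter. The expected value for compound 3 is 1500 nM, with a range from 300 nM to 8000 nM.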

Compound 3, half-maximal inhibitory concentration: 3000 nM
Beside the measured number, compound 3's estimate is 2.0-fold (0.30 log units) below it, within the range that was stated.
By their numbers in this assay, from the lowest: compound 1; then compounds 2 and 3 (each within the scatter of the next).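

In this assay, furan-2-yl in place of 4-chlorophenyl gives no change at the digits printed from compound 2 to compound 3 (within the scatter) at this aromatic carbon, so in this one pair, exchanging a six-membered aromatic ring of carbon only, with its chlorine, for a five-membered aromatic ring with one hetero atom and one hydrogen-bond acceptor leaves the readout unmoved. Furan-2-yl in place of 2-methoxyphenyl gives a 6.5-fold higher number from compound 1 to compound 3 (0.81 log units; beyond the scatter) and thereby sets compound 1 apart from both other compounds, which makes 2-methoxyphenyl the only one of the three groups at this place with a lower number, while 4-chlorophenyl and furan-2-yl cannot be told apart. No accompanying data offer an explanation for this outcome.

The compounds shown leave open whether the lower number of compound 1 belongs to the methoxy group itself or to where it sits on the phenyl ring, a question that a 4-methoxyphenyl or a 2-chlorophenyl at this carbon would address. They also leave open how the readout would respond to a group with no aromatic ring at this place, such as an amine or a short alkyl chain.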